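Compound 3 to compound 4: methyl in place of fluoro

The compounds below may be only part of what the source reports. "The series", "measured", "known", "first", "only" and "open" are said of these compounds alone.

The three measured compounds share one core and differ only in the substituent on the ring amine nitrogen: compound 1 `NC(=O)c1c(NC(=O)c2ccccc2Cl)sc2c1CCN(Cc1ccc(Cl)cc1)C2`, compound 2 `NC(=O)c1c(NC(=O)c2ccccc2Cl)sc2c1CCN(C(=O)Nc1ccccc1Cl)C2` and compound 3 `NC(=O)c1c(NC(=O)c2ccccc2Cl)sc2c1CCN(C(=S)Nc1ccccc1F)C2`. In a functional assay on HL-60 cells (Homo sapiens) for antiproliferative activity, with a stated time of 24 h (a higher number here means a weaker inhibitor, a lower number a stronger inhibitor), compound 1 gives 22500 nM, compound 2 gives 12500 nM and compound 3 gives 4970 nM. The steps are a 1.8-fold lower number from compound 1 to compound 2 (0.26 log units; within the scatter), a 4.5-fold lower number from compound 1 to compound 3 (0.66 log units; beyond the scatter) and a 2.5-fold lower number from compound 2 to compound 3 (0.40 log units; beyond the scatter), so compound 3 stands lowest of the three, beyond the scatter from both others.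

Compound 4 `Cc1ccccc1NC(=S)N1CCc2c(sc(NC(=O)c3ccccc3Cl)c2C(N)=O)C1` keeps the substituent of compound 3 and changes one atom on it: methyl in place of fluoro on an aromatic carbon. For the measured compounds named here, none of the measured steps touches a substituent on this ring; each exchanges the whole group on the ring amine nitrogen. No comparison in this assay therefore speaks to the size of this change, and the expectation rests on compound 3 alone. A step within the scatter is expected, a 1.0-fold higher number from compound 3 to compound 4 (0.00 log units; within the scatter). For compound 4 the estimate is 5000 nM, with a range from 2000 nM to 12500 nM.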

Compound 4, half-maximal inhibitory concentration: 22600 nM
Beside the measured number, compound 4's estimate is 4.5-fold (0.66 log units) below it; the measured number lies above the stated range.
By their numbers in this assay, from the lowest: compound 3; then compounds 2, 1 and 4 (each within the scatter of the next).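

In this assay, methyl in place of fluoro gives a 4.5-fold higher number from compound 3 to compound 4 (0.66 log units; beyond the scatter) and so shows that one atom on this aromatic ring, ortho to a large group, can alone produce a step beyond the scatter, which the earlier exchanges of the whole group on the ring amine nitrogen could not show. The lower number of compound 3 does not carry over to its methyl analogue, since a 1.8-fold higher number from compound 2 to compound 4 (0.26 log units; within the scatter) and a 1.0-fold higher number from compound 1 to compound 4 (0.00 log units; within the scatter) are both within the scatter, so the sulfur-containing linking group does not set compound 3 apart without the fluoro. Nothing at hand explains this step.

Open, as far as these compounds go, is how a chloro, methoxy or amino group would read at this place on the ring. Also open, from the compounds shown here alone, is whether the same exchange gives a step of this size on the oxygen-containing linking group of compound 2.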